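The source may hold more compounds than are shown below. What is called first, only, known or untested is meant among the compounds shown, and "the series" means these compounds.

Three compounds sharing one core differ only in the group attached to one aromatic carbon of that core. In a functional assay on Jurkat cells for inhibition of nuclear factor NF-kappa-B complex (Homo sapiens) (a higher number here means a weaker inhibitor, a lower number a stronger inhibitor), compound 1 `CCOC(=O)c1cnc(-c2cccc([N+](=O)[O-])c2)nc1NN1C(=O)C=C(C)C1=O` gives 7000 nM, compound 2 `CCOC(=O)c1cnc(-c2ccsc2)nc1NN1C(=O)C=C(C)C1=O` gives 100 nM, and compound 3 `CCOC(=O)c1cnc(-c2cc3ccccc3s2)nc1NN1C(=O)C=C(C)C1=O` gives 4000 nM. Compound 3 thus holds the second highest of the three numbers, close to compound 1 and far from compound 2. Compound 4 `CCOC(=O)c1cnc(S(=O)(=O)c2ccccc2)nc1NN1C(=O)C=C(C)C1=O` carries phenylsulfonyl in place of 1-benzothiophen-2-yl on an aromatic carbon. Going by the values given here, no measured step involves a phenylsulfonyl group, so this change is untested. Among the compounds with values here, the steps that bear on it are a 70-fold lower number from compound 1 to compound 2 (1.85 log units; beyond the scatter) and a 40-fold higher number from compound 2 to compound 3 (1.60 log units; beyond the scatter), showing that swapping this group can move the number greatly, while a 1.8-fold lower number from compound 1 to compound 3 (0.24 log units; within the scatter) shows it can also barely move it. Compound 4 is therefore expected to give about 4000 nM, within a wide range from 400 nM to 30000 nM. That estimate means an expected step of no change at the digits printed from compound 3 to compound 4 (within the scatter), with much uncertainty.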

Compound 4, half-maximal inhibitory concentration: 10000 nM
Beside the measured number, compound 4's estimate is 2.5-fold (0.40 log units) below it; the range from low to high includes it.
By their numbers in this assay, from the lowest: compound 2; then compounds 3, 1 and 4 (each within the scatter of the next, the first and the last beyond it).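

In this assay, going by these compounds alone, phenylsulfonyl, the only group here joined to the core through sulfur rather than through a ring carbon, gives a 1.4-fold higher number from compound 1 to compound 4 (0.15 log units; within the scatter) and a 2.5-fold higher number from compound 3 to compound 4 (0.40 log units; beyond the scatter) at this position. With a 100-fold higher number from compound 2 to compound 4 (2.00 log units; beyond the scatter) as well, thiophen-3-yl remains the only group shown that gives a low number, so a sulfonyl link does not bring back what the small thiophene ring gives. No measurement here explains this. Still open, going by these compounds, is whether a group with no aromatic ring, such as an amine or a morpholine, would fall nearer compound 2 or compound 4.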